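A few compounds are considered here, and "the series" means these few. Any claim that something is new, unique, unknown or untested is made for them only; others in the source may bear on it.

Compound 1 `CC(C)(N)C(=O)N[C@H](COCc1cccc(OC(F)(F)F)c1)c1nnnn1CCOC(=O)NCCCCO`: in a functional assay on cells for inhibition of growth hormone secretagogue receptor type 1 (Homo sapiens), read by FLIPR and calcium flux (on this read-out higher numbers stand for an effect only at larger amounts of compound and lower numbers for an effect already at smaller amounts), compound 1 gives 3.1 nM
Compound 2 `CC(C)(N)C(=O)N[C@H](COCc1ccccc1C#N)c1nnnn1CCOC(=O)NCCCCO`: compound 2 gives 1.26 nM
Compound 3 `CC(C)(N)C(=O)N[C@H](COCC1CCCCC1)c1nnnn1CCOC(=O)NCCCCO`: compound 3 gives 1.66 nM

Compound 3 stands second highest of the three numbers in this assay. Its nearest neighbour is compound 2, with a 1.3-fold higher number from compound 2 to compound 3 (0.12 log units; within the scatter), and its furthest is compound 1, with a 1.9-fold lower number from compound 1 to compound 3 (0.27 log units; within the scatter); both separations lie within the scatter, so the three compounds are not distinguished by these numbers.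

Compound 4 `CC(C)(N)C(=O)N[C@H](COCc1ccccc1-c1cccnc1)c1nnnn1CCOC(=O)NCCCCO` differs from compound 3 in one place: 2-(pyridin-3-yl)phenyl in place of cyclohexyl on a saturated chain carbon bound to an oxygen on a saturated carbon. The measured steps that bear on this change are those that swap the group on the same saturated chain carbon. Replacing an aromatic group by cyclohexyl gave a 1.9-fold lower number from compound 1 to compound 3 (0.27 log units; within the scatter) and a 1.3-fold higher number from compound 2 to compound 3 (0.12 log units; within the scatter), and swapping one aromatic group for another gave a 2.5-fold lower number from compound 1 to compound 2 (0.39 log units; beyond the scatter). Within this set the group at that position has moved the number only modestly at most, and two of the three steps stayed within the scatter. The expectation for compound 4 is therefore a step of a 1.2-fold higher number from compound 3 to compound 4 (0.08 log units; within the scatter), not clearly beyond the scatter in either direction. Compound 4 is estimated at 2 nM, with a range from 0.7 nM to 6 nM.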

Compound 4, half-maximal effective concentration: 1.18 nM
The estimate for compound 4 lay 1.7-fold (0.23 log units) above the measured number; the measured number falls inside the stated range.
By their numbers in this assay, from the lowest: compounds 4, 2, 3 and 1 (each within the scatter of the next, the first and the last beyond it).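

In this assay, among the compounds shown here, the earlier compounds carried only single-ring groups at this place, and compound 4 shows that a group of 12 heavy atoms with two aromatic rings can take the place of cyclohexyl, with its 6 heavy atoms, giving a 1.4-fold lower number from compound 3 to compound 4 (0.15 log units; within the scatter) and so no distinguishable change in the number. Pyridin-3-yl in place of cyano on an aromatic carbon likewise gives a 1.1-fold lower number from compound 2 to compound 4 (0.03 log units; within the scatter) and adds a second ring to the 2-substituted phenyl group with no separation from compound 2 in this read-out. Only the comparison with the 3-(trifluoromethoxy)phenyl group stands out, with a 2.6-fold lower number from compound 1 to compound 4 (0.42 log units; beyond the scatter) lying beyond the scatter, as does the step from that compound to compound 2, while its step to compound 3 stays within the scatter and goes against any clean split between it and the others.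

Nothing at hand accounts for why groups so different in size read alike at this place. As far as these compounds go, it remains open whether an amine or a carboxylic acid on the pyridine ring, or a longer chain in place of the single saturated carbon carrying the ring, would keep the number in this range.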